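This account rests on a few compounds, and the source may have more. Where it says the series, first, only, none or still open, it means among the compounds named here.

Measured in an assay on membranes from HEK293 cells for displacement of a labelled ligand from adenosine receptor A2b (Homo sapiens), read by scintillation counting, with a stated time of 30 min, tested at 1 uM; a lower number here means less inhibition, a higher number more inhibition at the concentration tested (going by the name of the read-out):

Compound 1 `CCCOC(=O)C1=C(C)NC(=S)NC1c1ccco1`: compound 1 gives 46%.
Compound 2 `CC1=C(C(=O)OCC(C)C)C(c2ccco2)NC(=S)N1`: compound 2 gives 18%.
Compound 3 `CCCOC(=O)C1=C(C)N(C)C(=O)NC1c1cccs1`: compound 3 gives 1%.

Compound 4 `CC1=C(C(=O)OCC(C)C)C(c2cccs2)NC(=O)N1C` has not yet been measured in this assay. It is built from compound 3 by one change: methyl in place of hydrogen on a saturated chain carbon bound to two saturated chain carbons. Exactly the same change turns compound 1 into compound 2: methyl in place of hydrogen on a saturated chain carbon bound to two saturated chain carbons. In both pairs the place of the change is described in the same words, so this is the same change made on two different starting compounds. How the core of compound 1 and the core of compound 3 differ from each other is not broken down here; they differ in more than one place.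

Going by the values given here, the one measured instance of the change gives a clear direction: a number 28 percentage points lower from compound 1 to compound 2 (beyond the scatter). Compound 3, however, starts from the lowest of the three measured numbers, close to the bottom of what the read-out can show, so there is very little room for the same downward movement to appear. The step for compound 4 is therefore expected to be small, a number 1 percentage points higher from compound 3 to compound 4 (within the scatter), because a number 28 percentage points lower from compound 1 to compound 2 (beyond the scatter) points downward while compound 3 already shows 1%. Compound 4 is estimated to give 2%, with the likely range running from -8% to 12%.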

Compound 4, a percentage reported as inhibition, at one concentration (the size of the read-out at that concentration, not a potency): 2%
Estimate against measurement, compound 4: no gap at the digits printed, within the range that was stated.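

In this assay, the swap from propoxy to isobutoxy gives a number 1 percentage points higher from compound 3 to compound 4 (within the scatter) on the core of compound 3, and set beside the earlier step on the core of compound 1, the two steps do not match: the same change on two cores in this assay, a number 28 percentage points lower (beyond the scatter) from compound 1 to compound 2 and a number 1 percentage points higher (within the scatter) from compound 3 to compound 4, 29 percentage points apart, beyond the scatter of two such steps. The clear drop seen on one core therefore did not reappear on the other, so the effect of this change cannot simply be carried from one core to the next in this series. This does not show that the extra methyl truly leaves the number level on the second core: compound 3 gives 1% and already sits close to the bottom of what the read-out can show, leaving almost no room for a fall to appear, and the two cores differ in more than one place, so no single difference can be held responsible for the mismatch.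

Still open, from the compounds shown here alone, is what a longer chain such as pentoxy, or a carboxylic acid or an amine in place of the propoxy ester, would do on either core. Also open, going by these compounds, is which of the differences between the two cores matters, a question that needs pairs differing in only one of those places.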